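The source may hold more compounds than are shown below. What is called first, only, known or untested is meant among the compounds shown, and "the series" means these compounds.

Compound 1 `Cc1ccc(S(=O)(=O)N(CC(=O)NCc2ccc(Cl)cc2)c2cccnc2)cc1` gives < 1000 nM in an assay on CHO cells for displacement of a labelled ligand from prostaglandin E2 receptor EP1 subtype (Homo sapiens) (a lower number here means a stronger inhibitor, a higher number a weaker inhibitor), which is a limit of the assay and not a number. Compound 2 `Cc1ccc(S(=O)(=O)N(CC(=O)NCc2ccc(Cl)cc2)c2cccc(C)n2)cc1` gives < 1000 nM in this assay, again only a limit. Compound 3 `Cc1ccc(S(=O)(=O)N(CC(=O)NCc2ccc(Cl)cc2)c2ccc(C)cn2)cc1` gives < 1000 nM in this assay, also a limit.

Compound 1 therefore stands on nothing firmer than a limit, and the two other values shown are limits as well; all three sit together, as the limit of < 1000 nM in this assay, at which 3 of the 3 values shown sit, records. The change that leads to compound 4 `Cc1ccc(S(=O)(=O)N(CC(=O)NCc2ccc(Cl)cc2)c2ccnn2C)cc1` is 1-methyl-1H-pyrazol-5-yl in place of pyridin-3-yl on a sulfonamide nitrogen. The measured steps that touch the same sulfonamide nitrogen are a step that the two limits leave unreadable from compound 1 to compound 2, a step that the two limits leave unreadable from compound 1 to compound 3 and a step that the two limits leave unreadable from compound 2 to compound 3; none of them can be read in size, since both ends of each are limits. What they do show is that three different aromatic rings on that nitrogen each kept the compound within the limit. For the pyrazole of compound 4 the data give no reason to expect a step in either direction beyond the scatter, so the expectation is that compound 4 too lands within the limit. The estimate for compound 4 is 300 nM, with a range from 30 nM to 1500 nM. The step this estimate means, a step that the limit leaves unreadable from compound 1 to compound 4, is expected to stay inside the usual scatter.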

Compound 4, inhibition constant: 398 nM
The estimate for compound 4 lay 1.3-fold (0.12 log units) below the measured number; the measured number falls inside the stated range.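

Among the compounds shown here, no step between compound 4 and compound 1, compound 2 or compound 3 can be read, because those three compounds are known only as a limit of the assay and not as numbers: the limit of < 1000 nM in this assay, at which 3 of the 4 values shown sit. The compounds shown leave open whether changing the aromatic ring on the sulfonamide nitrogen shifts the inhibition constant at all, and by how much.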